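The source may hold more compounds than are shown below. What is called first, only, known or untested is meant among the compounds shown, and "the series" means these compounds.

Compound 1: `Cc1nc(-c2ccc(C(F)(F)F)cc2)sc1CNc1ccc(C(=O)O)cc1`. Compound 2: `Cc1nc(-c2ccc(C(F)(F)F)cc2)sc1CNc1ccc([C@H]2C[C@@H]2C(=O)N(C)C)cc1`. Compound 3: `Cc1nc(-c2ccc(C(F)(F)F)cc2)sc1CNc1ccc([C@H]2C[C@@H]2C(=O)NC2CCNC2)cc1`.

In a functional assay on CHO cells for agonist activity at Free fatty acid receptor 1 (Homo sapiens) (on this read-out higher numbers stand for an effect only at larger amounts of compound and lower numbers for an effect already at smaller amounts), compound 1 gives only a limit, < 10000 nM, so no number is known for it. In this assay compound 2 gives 66.1 nM. Among the compounds with values here, because of the limit of < 10000 nM in this assay, at which 1 of the 2 values shown sits, the step that the limit leaves unreadable from compound 1 to compound 2 cannot be read, and compound 2 therefore stands as the only compound with a number in this assay; nothing shows it as stronger or weaker than any other.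

Compound 3 differs from compound 2 in one place: (pyrrolidin-3-yl)amino in place of dimethylamino on a carbonyl carbon. The amide thus changes from a fully substituted one to one carrying a hydrogen on its nitrogen and a basic ring. No measured step bears on this end of the molecule, since the only step shown is unreadable, so the expectation rests on the size of the change alone. A step of about a 1.5-fold higher number from compound 2 to compound 3 (0.18 log units; within the scatter) is expected, which would lie within the usual scatter. Compound 3 is therefore estimated at 100 nM in this assay, within a range from 25 nM to 400 nM.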

Compound 3, half-maximal effective concentration: 204 nM
The estimate for compound 3 lay 2.0-fold (0.31 log units) below the measured number; measured number inside the range.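

In this assay, the amide end of the molecule now has its first readable step: (pyrrolidin-3-yl)amino in place of dimethylamino on the carbonyl carbon gives a 3.1-fold higher number from compound 2 to compound 3 (0.49 log units; beyond the scatter). The change is modest, so this position tolerates a larger group with a five-membered ring and a hydrogen on the amide nitrogen, and compound 3 keeps a clear number of 204 nM. The steps that start from compound 1 cannot be read, since compound 1 gives only a limit: the limit of < 10000 nM in this assay, at which 1 of the 3 values shown sits.

The single step changes the size of the group, adds a ring and adds the amide hydrogen all at once, so it cannot be divided among these differences; a methylamino group would show what the amide hydrogen alone does, and an open 2-aminoethylamino chain would show whether the ring matters. From the compounds shown here alone, whether the step holds for other groups at this carbonyl carbon, such as a piperidin-4-ylamino group or a plain carboxylic acid on the cyclopropyl ring, also remains open.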